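A hydroxy-to-chloro swap on the aryl ketone ring

The source may report more compounds than this note shows. Statements on the series, on what has been measured and on what is new or still open speak of the compounds shown alone.

Of the compounds shown here, two built on the same core have been measured in a functional assay on HCT-15 cells (Homo sapiens) for cytotoxicity, read by sulforhodamine B assay, with a stated time of 24 h; on this read-out higher numbers stand for weaker inhibition of growth and lower numbers for stronger inhibition of growth. Compound 1 `COc1ccc(C(=O)/C=C/c2cc3ccccc3[nH]c2=O)cc1` carries a methoxy group on the six-membered aromatic ring of carbon only and gives 3180 nM in this assay. Its hydroxy counterpart is compound 2 `O=C(/C=C/c1cc2ccccc2[nH]c1=O)c1ccc(O)cc1`; in this assay compound 2 gives 2710 nM. Among the compounds with values here, the single step between them, a 1.2-fold lower number from compound 1 to compound 2 (0.07 log units; within the scatter), leaves the two numbers within the scatter of each other, so compound 2 simply holds the lower of the two numbers, with compound 1 nearest to it.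

Compound 3 `O=C(/C=C/c1cc2ccccc2[nH]c1=O)c1ccc(Cl)cc1` is the next variation: chloro in place of hydroxy on an aromatic carbon — that is, 4-hydroxyphenyl becomes 4-chlorophenyl, the new group sitting para to a large group. Within the data shown here, only one measured step touches this position, the exchange of methyl for hydrogen between compound 1 and compound 2, and it did not reach beyond the scatter. Among the measured compounds shown here, nothing measured so far shows that altering this small substituent moves the number appreciably. Compound 3 is therefore expected to stay close to compound 2, with a 1.1-fold lower number from compound 2 to compound 3 (0.04 log units; within the scatter) amounting to no step beyond the scatter. The estimate for compound 3 in this assay is 2500 nM, within a range from 1000 nM to 6500 nM.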

Compound 3, concentration for 50% growth inhibition: 3180 nM
Compound 3: middle estimate off by 1.3-fold (0.10 log units), on the low side; the range from low to high includes it.
By their numbers in this assay, from the lowest: compounds 2, 1 and 3 (each within the scatter of the next).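

Going from 4-hydroxyphenyl to 4-chlorophenyl in this assay gives a 1.2-fold higher number from compound 2 to compound 3 (0.07 log units; within the scatter) and stays within the scatter, and chloro in place of methoxy gives no change at the digits printed from compound 1 to compound 3 (within the scatter) and also stays within it. The earlier step changed only what sat on the oxygen, whereas here the oxygen itself gives way to a chlorine and the hydrogen-bond donor and acceptor counted for hydroxy are lost, yet methoxy, hydroxy and chloro at this place all remain within the scatter of one another. No measurement at hand bears on why these three groups read alike.

As far as these compounds go, it remains open whether any group at this place can move the number beyond the scatter, for instance an amine, a carboxylic acid or a longer chain such as butoxy. The compounds shown also leave open how the number responds to changes elsewhere, since the shared core and the link to the ketone are the same in all three.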